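Phenyl in place of 3,4-dimethoxyphenyl: working notes

The compounds below may be only part of what the source reports. "The series", "measured", "known", "first", "only" and "open" are said of these compounds alone.

Measured so far in a functional assay on ECa-109 cells (Homo sapiens) for cytotoxicity, read by MTT assay, with a stated time of 72 h; on this read-out higher numbers stand for weaker inhibition and lower numbers for stronger inhibition:
compound 1 `CN(C)c1ccc(C=C2C(=O)N(c3ccc(Cl)cc3)N(c3ccc(Cl)cc3)C2=O)cc1`: > 128000 nM (a limit)
compound 2 `COc1cccc(C=C2C(=O)N(c3ccc(Cl)cc3)N(c3ccc(Cl)cc3)C2=O)c1O`: 39000 nM
compound 3 `COc1ccc(C=C2C(=O)N(c3ccc(Cl)cc3)N(c3ccc(Cl)cc3)C2=O)cc1OC`: > 128000 nM (a limit)

Compound 3 gives > 128000 nM, which is a limit and not a number. Among the compounds with values here, the series so far is marked by the limit of > 128000 nM in this assay, at which 2 of the 3 values shown sit. The readable steps both involve compound 2: an at least 3.2-fold lower number from compound 1 to compound 2 (0.51 log units; beyond the scatter) and an at least 3.2-fold higher number from compound 2 to compound 3 (0.51 log units; beyond the scatter). From the compounds shown here alone, the remaining one, a step that the two limits leave unreadable from compound 1 to compound 3, stays open.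

The next compound is compound 4 `O=C1C(=Cc2ccccc2)C(=O)N(c2ccc(Cl)cc2)N1c1ccc(Cl)cc1`, with the change phenyl in place of 3,4-dimethoxyphenyl on a double-bonded chain carbon bound to a double-bonded ring carbon. Within the data shown here, compound 4 lacks the 2-hydroxy-3-methoxyphenyl of compound 2, the only compound with a number, at 39000 nM. Weak inhibition near the limit of compound 3 is therefore expected in this assay, with no clear step beyond the scatter and a second limit quite possible. The estimated step is an at least 1.4-fold lower number from compound 3 to compound 4 (0.15 log units; that floor lies within the scatter). For compound 4 the estimated value is 90000 nM, with an expected range from 30000 nM to 260000 nM.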

Compound 4, half-maximal inhibitory concentration: 32700 nM
For compound 4 the middle estimate is 2.8-fold (0.44 log units) above the measured one; the range from low to high includes it.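

At this position, on a double-bonded chain carbon bound to a double-bonded ring carbon, a measurable value in this assay does not depend on the 2-hydroxy-3-methoxyphenyl of compound 2: exchanging it for phenyl gives a 1.2-fold lower number from compound 2 to compound 4 (0.08 log units; within the scatter). Plain phenyl also separates from both substituted rings that gave limits, with an at least 3.9-fold lower number from compound 3 to compound 4 (0.59 log units; beyond the scatter) and an at least 3.9-fold lower number from compound 1 to compound 4 (0.59 log units; beyond the scatter), although compound 2 goes against any reading that substituents on this ring always weaken inhibition. The values of compound 1 and compound 3 are limits and not numbers: the limit of > 128000 nM in this assay, at which 2 of the 4 values shown sit.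

The step from compound 1 to compound 3 still cannot be read. The compounds shown leave open how a carboxylic acid or a primary amine on this phenyl would read out, and whether either would stay level with compound 2 and compound 4.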